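Clearance expected to hold after a substituent rearrangement

The source may report more compounds than this note shows. Statements on the series, on what has been measured and on what is new or still open speak of the compounds shown alone.

In an in vitro ADME assay on microsomes from liver (Homo sapiens) for metabolic stability, with a stated time of 15 min (on this read-out lower numbers stand for slow clearance and higher numbers for fast clearance), compound 1 `CCc1nn2c(-c3c(COC)cc(OC)cc3OC)cccc2c1N(CC1CCOCC1)CC1CC1` gives 530 mL.min-1.g-1, compound 2 `CCCN(CC1CCOCC1)c1c(CC)nn2c(-c3c(OC)cc(COC)cc3OC)cccc12` gives 700 mL.min-1.g-1 and compound 3 `CCc1nn2c(-c3c(C)cc(OC)cc3OC)cccc2c1N(CC1CCOCC1)CC1CC1` gives 450 mL.min-1.g-1, which places compound 3 within the scatter of both others. Compound 4 `CCc1nn2c(-c3c(OC)cc(C)cc3OC)cccc2c1N(CC1CCOCC1)CC1CC1` holds the same atoms as compound 3, joined differently: 2,6-dimethoxy-4-methylphenyl in place of 2,4-dimethoxy-6-methylphenyl on an aromatic carbon. Among the measured compounds shown here, the one measured step that bears on this, a 1.2-fold lower number from compound 1 to compound 3 (0.07 log units; within the scatter), alters a different group on the same substituent and stays within the scatter. For the measured compounds named here, no measured step makes this exact exchange, so the expectation rests on that small step alone. The expected change is a 1.1-fold higher number from compound 3 to compound 4 (0.03 log units; within the scatter), with no shift beyond the scatter. Compound 4 is estimated at 480 mL.min-1.g-1, with an expected range of 250 mL.min-1.g-1 to 900 mL.min-1.g-1.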

Compound 4, intrinsic clearance in microsomes: 440 mL.min-1.g-1
Compound 4: the middle estimate sits 1.1-fold (0.04 log units) above what was measured, within the range that was stated.
By their numbers in this assay, from the lowest: compounds 4, 3, 1 and 2 (each within the scatter of the next).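

In this assay, among the compounds shown here, the exchange of 2,4-dimethoxy-6-methylphenyl for 2,6-dimethoxy-4-methylphenyl on this aromatic carbon gives a 1.0-fold lower number from compound 3 to compound 4 (0.01 log units; within the scatter) and is the first measured rearrangement of this substituent. For this pair, joining the same methoxy and methyl groups differently leaves clearance within the scatter. No evidence is available to explain this result. The compounds shown leave open whether this read-out would also hold with an amine or a carboxylic acid in place of the methyl group of 2,6-dimethoxy-4-methylphenyl.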